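Amide variation on the shared core against NF-kappa-B

The source may hold more compounds than are shown below. What is called first, only, known or untested is meant among the compounds shown, and "the series" means these compounds.

Measured compounds:
compound 1, `COc1ccc2c(c1)OC(c1cc(OC)c(OC)c(OC)c1)C(C(=O)N1CCCCC1)=C2` — in a functional assay for inhibition of nuclear factor NF-kappa-B complex (Homo sapiens) (on this read-out lower numbers stand for stronger inhibition and higher numbers for weaker inhibition), compound 1 gives > 50000 nM, a limit of the assay rather than a number.
compound 2, `COc1ccc2c(c1)OC(c1cc(OC)c(OC)c(OC)c1)C(C(=O)N(C)OC)=C2` — compound 2 gives 11700 nM.
compound 3, `CCCCNC(=O)C1=Cc2ccc(OC)cc2OC1c1cc(OC)c(OC)c(OC)c1` — compound 3 gives 25500 nM.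

Compound 1 therefore stands only at the limit of > 50000 nM in this assay, at which 1 of the 3 values shown sits; where it sits beyond that is not known. Compound 4, `CCNC(=O)C1=Cc2ccc(OC)cc2OC1c1cc(OC)c(OC)c(OC)c1`, differs from compound 1 by ethylamino in place of piperidin-1-yl on a carbonyl carbon. Two measured steps leave the same group from the same carbonyl carbon: an at least 4.2-fold lower number from compound 1 to compound 2 (0.63 log units; beyond the scatter) and an at least 1.9-fold lower number from compound 1 to compound 3 (0.29 log units; that floor lies within the scatter). The second of these, with butylamino entering, resembles the change to ethylamino most closely, so a lower number than compound 1 is expected, of about the size seen for compound 3. Compound 4 is thus estimated at 25000 nM, between 9000 nM and 60000 nM, which would mean an at least 2.0-fold lower number from compound 1 to compound 4 (0.30 log units; that floor lies within the scatter).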

Compound 4, half-maximal inhibitory concentration: > 50000 nM
Compound 4 ended at the assay's limit; the forecaster's own chance of this, stated with the estimate: 35%; middle value at least 2.0-fold (0.30 log units) away from the limit.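

In this assay compound 4 gives a limit of the assay, not a number: the limit of > 50000 nM in this assay, at which 2 of the 4 values shown sit.
The step from compound 1 to compound 4 cannot be read, so ethylamino in place of piperidin-1-yl shows no readable gain.
Against the other amides, an at least 4.2-fold higher number from compound 2 to compound 4 (0.63 log units; beyond the scatter) places ethylamino clearly behind methoxy(methyl)amino, while an at least 1.9-fold higher number from compound 3 to compound 4 (0.29 log units; that floor lies within the scatter) gives only a floor, so shortening butylamino to ethylamino is not shown to matter.

As far as these compounds go, whether a longer chain such as hexylamino, or a benzylamino or morpholin-4-yl amide, would read lower than compound 2 stays open. From the compounds shown here alone, how far compound 1 and compound 4 lie beyond the limit also stays open.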